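A few compounds are considered here, and "the series" means these few. Any claim that something is new, unique, unknown or untested is made for them only; others in the source may bear on it.

In an ADME assay on the whole organism (Mus musculus, strain CD-1) for pharmacokinetics (on this read-out lower numbers stand for slow clearance and higher numbers for fast clearance), compound 2 `COc1cc([C@](O)(CCN(C)C)[C@@H](c2cc3cc(Br)ccc3nc2OC)c2cccc(OC)c2F)cc(OC(F)F)n1` gives 9.7 mL/min/kg, the middle of three numbers. Compound 1 `CCOc1cc([C@](O)(CCN(C)C)[C@@H](c2cc3cc(Br)ccc3nc2OC)c2cccc(OC)c2F)cc(OC)n1` gives 19 mL/min/kg and compound 3 `COc1cc([C@](O)(CCN(C)C)[C@@H](c2cc3cc(Br)ccc3nc2OC)c2ccnc(OC)c2OC)cc(OC(F)F)n1` gives 8.7 mL/min/kg, but the steps linking each of them to compound 2 lie within the usual scatter, so the three values are not clearly separated.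

Compound 4 `CCSc1cc([C@](O)(CCN(C)C)[C@@H](c2cc3cc(Br)ccc3nc2OC)c2cccc(OC)c2F)cc(SCC)n1` has not been measured yet. It differs from compound 2 by a single exchange: a group of 12 heavy atoms (9 carbon, 1 nitrogen, 2 sulfur; one six-membered aromatic ring with 1 hetero atom) in place of a group of 12 heavy atoms (7 carbon, 1 nitrogen, 2 oxygen, 2 fluorine; one six-membered aromatic ring with 1 hetero atom), on a saturated chain carbon bound to an oxygen on a saturated carbon and two saturated chain carbons. The group that enters brings sulfur and has no oxygen or fluorine.

Going by the values given here, no measured compound contains sulfur, so no measured step shows this exchange directly. The closest guide is a 2.0-fold lower number from compound 1 to compound 2 (0.29 log units; within the scatter), where difluoromethyl replaces ethyl on an oxygen on an aromatic ring. That change lies within the group being exchanged in compound 4. The other step, a 1.1-fold lower number from compound 2 to compound 3 (0.05 log units; within the scatter), concerns a different part of the molecule and offers little guidance here.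

The expectation therefore leans on compound 1, which carries an ethyl group and gives 19 mL/min/kg. A modest move to a higher number is expected in this assay, no larger than the scatter. The expected step is a 1.6-fold higher number from compound 2 to compound 4 (0.22 log units; within the scatter). For compound 4 the estimated value is 16 mL/min/kg, with an expected range from 7 mL/min/kg to 38 mL/min/kg.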

Compound 4, clearance: 3.6 mL/min/kg
For compound 4 the middle estimate is 4.4-fold (0.65 log units) above the measured one, and the stated range ends above it.
By their numbers in this assay, from the lowest: compound 4; then compounds 3, 2 and 1 (each within the scatter of the next, the first and the last beyond it).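

In this assay, this exchange on the saturated chain carbon is the first change among these compounds to move the number beyond the usual scatter: the aromatic ring group that brings sulfur, in place of the one holding oxygen and fluorine, gives a 2.7-fold lower number from compound 2 to compound 4 (0.43 log units; beyond the scatter). The distance from the other neighbour is wider still, a 5.3-fold lower number from compound 1 to compound 4 (0.72 log units; beyond the scatter), so the presence of an ethyl group does not by itself go with a higher number, since compound 1 and compound 4 both carry ethyl yet lie clearly apart. Going by these compounds alone, the aromatic ring group at this place can therefore shift clearance by more than the earlier steps could show, and here the shift is towards the slow end of the scale.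

No measurement shown explains why the number falls. Going by these compounds, compound 4 replaces both ring substituents at once, so it remains open how much each sulfur-bearing group contributes, and whether a propyl chain on sulfur or an amine on the same ring would keep the number this low.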